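A few compounds are considered here, and "the series" means these few. Any claim that something is new, unique, unknown or untested is made for them only; others in the source may bear on it.

In an ADME assay for lipophilicity (on this read-out lower numbers stand for lower lipophilicity and higher numbers for higher lipophilicity), compound 1, `CCCc1oc(C)cc(=O)c1O`, gives 1.4. Compound 2, `CCCCc1oc(C)cc(=O)c1O`, differs from compound 1 in one place: methyl in place of hydrogen on a saturated chain carbon, three bonds along the chain from an aromatic carbon. In this assay compound 2 gives 1.92, which makes the step of a number 0.52 log units higher from compound 1 to compound 2 (beyond the scatter). Compound 3, `CCCn1cccc(O)c1=O`, rests on a different core; the difference between the two cores is not broken down here. In this assay compound 3 gives 0.69, the lowest of the three numbers, beyond the scatter from both compound 1 and compound 2. Compound 4, `CCCCn1cccc(O)c1=O`, has not yet been measured in this assay. It differs from compound 3 by methyl in place of hydrogen on a saturated chain carbon, three bonds along the chain from an aromatic nitrogen. This is the same kind of change as that from compound 1 to compound 2, but the surroundings differ: on the core of compound 1 the saturated chain carbon lies three bonds along the chain from an aromatic carbon, on the core of compound 3 three bonds along the chain from an aromatic nitrogen. Taking the step of a number 0.52 log units higher from compound 1 to compound 2 (beyond the scatter) as the guide, compound 4 is expected to rise above compound 3 by a number 0.51 log units higher from compound 3 to compound 4 (beyond the scatter). Compound 4 is thus estimated at 1.2, likely between 0.9 and 1.5.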

Compound 4, distribution coefficient: 1.18
Compound 4: the middle estimate sits 0.02 log units above what was measured, within the range that was stated.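

In this assay, going from propyl to butyl on the second core gives a number 0.49 log units higher from compound 3 to compound 4 (beyond the scatter). Set beside the earlier step, the two cannot be told apart, so in this pair of cores the change carries over with its size intact: the same change on two cores in this assay, a number 0.52 log units higher (beyond the scatter) from compound 1 to compound 2 and a number 0.49 log units higher (beyond the scatter) from compound 3 to compound 4, 0.03 log units apart, within the scatter of two such steps. For the compounds shown here, this shows only that one small change behaves alike on these two cores in this one assay; it does not show that the step would hold on a third core, that other changes would carry over in the same way, or why compounds on the two cores stand at different levels.

The compounds shown leave open whether a longer chain would keep raising the number by a similar step on either core. They also leave open whether a different group, such as an amine or a carboxylic acid in place of the added methyl, would carry from one core to the other as faithfully.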